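Removing the Methoxy Group from Compound 3

The source may report more compounds than this note shows. Statements on the series, on what has been measured and on what is new or still open speak of the compounds shown alone.

Measured in a functional assay on MCF7 cells (Homo sapiens) for cytotoxicity, read by MTT assay, with a stated time of 72 h; a lower number here means a stronger inhibitor, a higher number a weaker inhibitor:
- Compound 1 `CNC(=O)c1cc(Oc2ccc(C3=NNC(c4cccc(Br)c4)C3)cc2)ccn1`: 1960 nM
- Compound 2 `CNC(=O)c1cc(Oc2ccc(C3=NNC(c4cccc([N+](=O)[O-])c4)C3)cc2)ccn1`: 35400 nM
- Compound 3 `CNC(=O)c1cc(Oc2ccc(C3=NNC(c4ccc(OC)cc4)C3)cc2)ccn1`: 11000 nM

Of these three numbers, the middle one belongs to compound 3. The next structure, compound 4 `CNC(=O)c1cc(Oc2ccc(C3=NNC(c4ccccc4)C3)cc2)ccn1`, has hydrogen in place of methoxy on an aromatic carbon, para to a large group: hydrogen in place of methoxy on an aromatic carbon.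

Within the data shown here, no measured step removes a group from this ring outright, so the evidence is indirect. Swapping the aryl group gave a 5.6-fold higher number from compound 1 to compound 3 (0.75 log units; beyond the scatter) and a 3.2-fold lower number from compound 2 to compound 3 (0.51 log units; beyond the scatter), while the widest step was an 18-fold higher number from compound 1 to compound 2 (1.26 log units; beyond the scatter). These steps do not show which way the number should move. In this assay the expected step is therefore small, a 1.4-fold lower number from compound 3 to compound 4 (0.14 log units; within the scatter), and not beyond the scatter. The estimate for compound 4 is 8000 nM, with an expected range from 2500 nM to 25000 nM.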

Compound 4, half-maximal inhibitory concentration: 1240 nM
Estimate against measurement, compound 4: 6.5-fold (0.81 log units) above, and the stated range ends above it.
By their numbers in this assay, from the lowest: compounds 4 and 1 (each within the scatter of the next); then compound 3; then compound 2.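

In this assay removing methoxy gives an 8.9-fold lower number from compound 3 to compound 4 (0.95 log units; beyond the scatter) and so the plain phenyl ring does far better here than the 4-methoxyphenyl ring. Hydrogen in place of nitro gives a 29-fold lower number from compound 2 to compound 4 (1.46 log units; beyond the scatter) and hydrogen in place of bromo gives a 1.6-fold lower number from compound 1 to compound 4 (0.20 log units; within the scatter) which stays within the scatter, so the bromo group of compound 1 is not needed to reach that level. Nothing measured here explains these steps.

Still open, from the compounds shown here alone, is whether an amine or a carboxylic acid on this ring would match plain phenyl or fall away as methoxy and nitro do.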